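The source may hold more compounds than are shown below. What is called first, only, known or untested is meant among the compounds shown, and "the series" means these compounds.

Measured so far:
compound 1, `Oc1c(C(Nc2ccccn2)c2ccccc2F)ccc2cccnc12`, which in an assay for inhibition of protein disulfide-isomerase (Homo sapiens), with a stated time of 1 h (on this read-out higher numbers stand for weaker inhibition and lower numbers for stronger inhibition), gives 470 nM
compound 2, `Cc1ccnc(NC(c2ccc(F)cc2)c2ccc3cccnc3c2O)c1`, which in this assay gives 140 nM
compound 3, `Oc1ccc2[nH]ccc2c1C(c1ccc(F)cc1)N1CCCCC1`, which in this assay gives 1810 nM

Among these three, compound 2 carries the lowest number in this assay, meaning the strongest inhibition: compound 1 sits higher by a gap beyond the usual scatter of repeated measurements, and compound 3 higher still, well beyond it.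

Compound 4, `CCc1ccc(C(Nc2cc(C)ccn2)c2ccc3cccnc3c2O)cc1`, has not yet been measured. It differs from compound 2 in a single place: ethyl in place of fluoro on an aromatic carbon. For the measured compounds named here, no measured pair in this set differs by exactly this change, so there is no direct guide to how large its effect may be. With nothing in the data pointing to a sharp shift in either direction, the expected step is a 1.4-fold higher number from compound 2 to compound 4 (0.15 log units; within the scatter), a change of modest size that may well stay within the scatter. On that basis compound 4 is estimated at 200 nM in this assay, with a range from 70 nM to 600 nM.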

Compound 4, half-maximal inhibitory concentration: 5390 nM
For compound 4 the middle estimate is 27-fold (1.43 log units) below the measured one; the whole stated range lies below it.
By their numbers in this assay, from the lowest: compound 2; then compound 1; then compound 3; then compound 4.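

In this assay, the group on this aromatic carbon turns out to matter a great deal: going from 4-fluorophenyl to 4-ethylphenyl brings a 39-fold higher number from compound 2 to compound 4 (1.59 log units; beyond the scatter) and so a far weaker inhibition. The change is modest by count, with fluoro's 1 heavy atom giving way to ethyl's 2, yet this step is large. The earlier compounds offered no pair differing in one place, so they could not show how much this position counts, and nothing in the data shown explains the size of the step.

Going by these compounds, it remains open whether chloro, methoxy or an amine at this carbon would keep the number close to that of compound 2, or whether a longer chain such as propyl would weaken inhibition further. A single step also cannot show whether the loss grows gradually with chain length or appears suddenly with ethyl.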